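A methoxy added to a chalcone pyrazole: what to expect

The compounds below may be only part of what the source reports. "The series", "measured", "known", "first", "only" and "open" are said of these compounds alone.

Three compounds share a core in which a pyrazole carries an aryl group on one side and an enone on the other. Compound 1 `COc1ccc(-c2cc(/C=C/C(=O)c3ccc(N)cc3)[nH]n2)cc1` bears an aminophenyl on the carbonyl carbon. In a functional assay on U-251 cells (Homo sapiens) for cytotoxicity, read by sulforhodamine B assay, with a stated time of 48 h, tested at 0.1 uM (on this read-out higher numbers stand for a weaker effect at the one concentration tested and lower numbers for a stronger effect), compound 1 gives 90%. Compound 2 `COc1ccc(C(=O)/C=C/c2cc(-c3cc(OC)c(OC)c(OC)c3)n[nH]2)cc1OC` gives 95%, and compound 3 `COc1cc(-c2cc(/C=C/C(=O)c3ccc(F)c(F)c3)[nH]n2)cc(OC)c1OC` gives 96%. All three numbers lie within the usual scatter of one another, so on these data compound 1 cannot be set apart from compound 2 or compound 3. Within the data shown here, the one step between neighbours, 3,4-difluorophenyl in place of 3,4-dimethoxyphenyl on a carbonyl carbon, is a number 1 percentage points higher from compound 2 to compound 3 (within the scatter), a change that leaves the read-out where it was.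

Compound 4 `COc1ccc(-c2cc(/C=C/C(=O)c3ccc(N)cc3)[nH]n2)cc1OC` differs from compound 1 by methoxy in place of hydrogen on an aromatic carbon. Among the measured compounds shown here, no measured pair shows this particular change, and the only step at hand, on a different ring, was flat. For the measured compounds named here, with every number so far close to the top of the scale, nothing in the data points to a move in either direction, and the step from compound 1 is expected to be a number 2 percentage points higher from compound 1 to compound 4 (within the scatter). Compound 4 is therefore estimated at 92%, with a range from 80% to 100%.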

Compound 4, a percentage reported as activity, at one concentration (the size of the read-out at that concentration, not a potency): 95%
Estimate against measurement, compound 4: 3 percentage points below, within the range that was stated.
By their numbers in this assay, from the lowest: compounds 1, 2, 4 and 3 (each within the scatter of the next).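

Among these compounds, the first measured pair for this change shows that methoxy in place of hydrogen on an aromatic carbon, ortho to a methoxy group and meta to a large group, gives in this assay a step that is a number 5 percentage points higher from compound 1 to compound 4 (within the scatter). This adds a second single-place change to the one on the other aryl ring, a number 1 percentage points higher from compound 2 to compound 3 (within the scatter), so among these four compounds neither change separates a pair, and none goes against that reading. The data offer nothing that would explain this result, and no measurement of any property of the compounds accompanies it.

The compounds shown leave open whether a hydroxyl, a chlorine atom or a longer chain such as ethoxy on this same aromatic carbon would give a number beyond the scatter of compound 1. On these data alone, it also remains open whether the added methoxy would read the same if a carboxylic acid took the place of the amine on the aminophenyl group of compound 4.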